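Aryl swap on the ring nitrogen: compound 3 to compound 4

The source may report more compounds than this note shows. Statements on the series, on what has been measured and on what is new or still open speak of the compounds shown alone.

Compound 1, `O=C1CC(c2nc(-c3cccc(Cl)c3)no2)CN1c1ccc(Cl)c(Cl)c1`, was tested in an in vitro functional assay on HEK293-A cells for negative allosteric modulation of metabotropic glutamate receptor 5 (Homo sapiens), read by FLIPR and calcium flux; a higher number here means a weaker inhibitor, a lower number a stronger inhibitor: compound 1 gives > 10000 nM, a limit of the assay and not a number. Compound 2, `Cc1cccc(N2CC(c3nc(-c4cccc(Cl)c4)no3)CC2=O)c1`, gives 2300 nM in this assay. Compound 3, `Cc1ccc(N2CC(c3nc(-c4cccc(Cl)c4)no3)CC2=O)cc1C`, also returns only a limit; in this assay compound 3 gives > 10000 nM. Compound 3 thus stands at the limit of > 10000 nM in this assay, at which 2 of the 3 values shown sit, so its position is known only as a ceiling.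

The steps read: an at least 4.3-fold lower number from compound 1 to compound 2 (0.63 log units; beyond the scatter); an at least 4.3-fold higher number from compound 2 to compound 3 (0.63 log units; beyond the scatter); a step that the two limits leave unreadable from compound 1 to compound 3.

Compound 4, `O=C1CC(c2nc(-c3cccc(Cl)c3)no2)CN1c1cccc(Cl)c1`, differs from compound 3 by 3-chlorophenyl in place of 3,4-dimethylphenyl on an amide-type nitrogen in a ring. The aryl on the ring nitrogen of compound 4 carries a single substituent, as in compound 2, and the step from compound 2 to compound 3 shows that adding a second methyl pushed the number past the limit. Removing it is therefore expected to bring the number back down, giving an at least 3.3-fold lower number from compound 3 to compound 4 (0.52 log units; beyond the scatter). Compound 4 is estimated at 3000 nM, with a range from 1000 nM to 10000 nM.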

Compound 4, half-maximal inhibitory concentration: 1100 nM
Estimate against measurement, compound 4: 2.7-fold (0.44 log units) above, and the stated range covers the measured number.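

Both aryl groups with two substituents now stand apart from both with one: the change to 3-chlorophenyl on the amide-type nitrogen lowers the number in this assay whether the starting group carries two methyls (an at least 9.0-fold lower number from compound 3 to compound 4 (0.95 log units; beyond the scatter)) or two chloros (an at least 9.0-fold lower number from compound 1 to compound 4 (0.95 log units; beyond the scatter)). Among the groups with one substituent, the identity of that substituent also registers, with chloro in place of methyl (a 2.1-fold lower number from compound 2 to compound 4 (0.32 log units; beyond the scatter)). The two larger steps are bounds only, as compound 1 and compound 3 each return a limit of the assay and not a number: the limit of > 10000 nM in this assay, at which 2 of the 4 values shown sit.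

From the compounds shown here alone, how an unsubstituted phenyl on the ring nitrogen would read remains open. Also open, going by these compounds, is whether a methoxy or trifluoromethyl group in place of the chloro of compound 4 would follow the same trend.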